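The source may hold more compounds than are shown below. What is called first, only, known or untested is meant among the compounds shown, and "the series" means these compounds.

Measured so far in a toxicity assay on HEK293 cells (Homo sapiens) for cytotoxicity, read by resazurin assay, with a stated time of 24 h; a lower number here means a stronger inhibitor, a higher number a weaker inhibitor:

- Compound 1 `Cc1ccc(NCc2cn(-c3ccc(C(F)(F)F)cc3)nc2-c2ccc(C(=O)O)cc2)cc1Cl`: > 12 ug/mL
- Compound 2 `CC(C)(C)c1ccc(NCc2cn(-c3ccc(C(F)(F)F)cc3)nc2-c2ccc(C(=O)O)cc2)cc1`: 8 ug/mL

Compound 1 stands at a limit of the assay, > 12 ug/mL, and not at a number. Compound 3 `O=C(O)c1ccc(-c2nn(-c3ccc(C(F)(F)F)cc3)cc2CNc2ccc(Br)c(C(F)(F)F)c2)cc1` keeps the core of compound 1 and changes one group: 4-bromo-3-(trifluoromethyl)phenyl in place of 3-chloro-4-methylphenyl on an amine nitrogen. Among the measured compounds shown here, only one measured step touches that amine nitrogen, and it brings in a different group, so it is a rough guide. Going by an at least 1.5-fold lower number from compound 1 to compound 2 (0.17 log units; that floor lies within the scatter), a small move to a lower number is expected in this assay, or none beyond the scatter. The expected step is an at least 1.5-fold lower number from compound 1 to compound 3 (0.17 log units; that floor lies within the scatter). The estimated value for compound 3 is 8 ug/mL, with an expected range from 4 ug/mL to 16 ug/mL. A reading that gives only a limit would also not be a surprise.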

Compound 3, half-maximal inhibitory concentration: > 12 ug/mL
Compound 3 ended at the assay's limit (the forecaster's own chance of this, stated with the estimate: 40%); middle value at least 1.5-fold (0.17 log units) from the limit.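

In this assay, compound 3, with 4-bromo-3-(trifluoromethyl)phenyl on the amine nitrogen, gives > 12 ug/mL, which is a limit of the assay and not a number. The step between compound 1 and compound 3 cannot be read, because both stop at the same limit: the limit of > 12 ug/mL in this assay, at which 2 of the 3 values shown sit.

Among the compounds shown here, the one readable step is an at least 1.5-fold higher number from compound 2 to compound 3 (0.17 log units; that floor lies within the scatter), so this floor does not separate the 4-(tert-butyl)phenyl and 4-bromo-3-(trifluoromethyl)phenyl groups at this position.

On these data alone, how far beyond the limit compound 1 and compound 3 truly lie remains open, and so does whether they differ at all. Also open, as far as these compounds go, is how a phenyl group carrying an amine or a carboxylic acid would read on this amine nitrogen in this assay.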